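The compounds below may be only part of what the source reports. "The series", "measured", "known", "first", "only" and "open" are said of these compounds alone.

Three compounds have been measured in a physicochemical assay for solubility, read by HPLC, at pH 7; a higher number here means a more soluble compound, a lower number a less soluble compound:

compound 1 `O=[N+]([O-])c1cn2c(n1)OC[C@@H](OCCOc1ccc(-c3ccc(OC(F)(F)F)cc3)cc1)C2` — 0.68 ug/mL
compound 2 `O=[N+]([O-])c1cn2c(n1)OC[C@@H](OCC#Cc1ccc(-c3ccc(OC(F)(F)F)cc3)cc1)C2` — 0.07 ug/mL
compound 3 `O=[N+]([O-])c1cn2c(n1)OC[C@@H](OCCOc1ccc(OC(F)(F)F)cc1)C2` — 50 ug/mL

Compound 1 and compound 3 differ in a single place: trifluoromethoxy in place of 4-(trifluoromethoxy)phenyl on an aromatic carbon. That change produced a 74-fold higher number from compound 1 to compound 3 (1.87 log units; beyond the scatter). Compound 2 has the lowest number of the three, sitting well under compound 1 and far under compound 3. The difference between the core of compound 2 and the core of compound 1 is not broken down here.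

Compound 4 `O=[N+]([O-])c1cn2c(n1)OC[C@@H](OCC#Cc1ccc(OC(F)(F)F)cc1)C2` has not yet been measured in this assay. Going by the values given here, it differs from compound 2 by trifluoromethoxy in place of 4-(trifluoromethoxy)phenyl on an aromatic carbon, which is the same change as the one made from compound 1 to compound 3. Because the step of a 74-fold higher number from compound 1 to compound 3 (1.87 log units; beyond the scatter) was large, a step of comparable direction and size is expected from compound 2 to compound 4, namely a 57-fold higher number from compound 2 to compound 4 (1.76 log units; beyond the scatter). This expectation rests on a single measured pair, so its size is uncertain. Compound 4 is estimated at 4 ug/mL, with a likely range from 1 ug/mL to 15 ug/mL.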

Compound 4, solubility: 0.77 ug/mL
Beside the measured number, compound 4's estimate is 5.2-fold (0.72 log units) above it, outside the stated range (below it).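

In this assay the replacement of 4-(trifluoromethoxy)phenyl by trifluoromethoxy gave an 11-fold higher number from compound 2 to compound 4 (1.04 log units; beyond the scatter) and, on the other core, a 74-fold higher number from compound 1 to compound 3 (1.87 log units; beyond the scatter) with both steps beyond the scatter. The direction therefore carried from the core of compound 1 to the core of compound 2, but the size did not carry in full, as the step on the core of compound 2 is the smaller of the two, and two pairs cannot show how far the size would vary on a further core. Nothing available here bears on why the two steps differ in size.

The compounds shown leave open how an amine or a carboxylic acid would behave in place of trifluoromethoxy on the same aromatic carbon. They also leave open whether the change would carry in the same direction on a core with a longer chain.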